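Growing the chain substituent from methyl to isopropyl

A few compounds are considered here, and "the series" means these few. Any claim that something is new, unique, unknown or untested is made for them only; others in the source may bear on it.

Measured so far:
compound 1 `COc1ccccc1N1CCN(CCC(Oc2ccc(NC(=O)c3ccccc3OCCCC(=O)O)cc2)c2ccc(C)cc2)CC1` — 79.4 nM
compound 2 `CCc1ccc(C(CCN2CCN(c3ccccc3OC)CC2)Oc2ccc(NC(=O)c3ccccc3OCCCC(=O)O)cc2)cc1` — 200 nM

In an assay on Prostate gland (Oryctolagus cuniculus) for inhibition of Adrenergic receptor alpha-1 (Homo sapiens) (on this read-out higher numbers stand for weaker binding and lower numbers for tighter binding), compound 2 gives 200 nM, the highest of the two numbers; its nearest neighbour is compound 1 at 79.4 nM. Among the compounds with values here, the one measured step, a 2.5-fold higher number from compound 1 to compound 2 (0.40 log units; beyond the scatter), comes from isopropyl in place of methyl on a saturated chain carbon bound to an aromatic carbon applied at the same place. Compound 3 `COc1ccccc1N1CCN(CCC(Oc2ccc(NC(=O)c3ccccc3OCCCC(=O)O)cc2)c2ccc(CC(C)C)cc2)CC1` takes this change one stage further. Within the data shown here, only that single step bears on it, so a further modest rise is expected, a 2.0-fold higher number from compound 2 to compound 3 (0.30 log units; within the scatter), though with a wide margin. Compound 3 is therefore estimated at 400 nM, between 150 nM and 1000 nM.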

Compound 3, dissociation constant: 6310 nM
Estimate against measurement, compound 3: 16-fold (1.20 log units) below, outside the stated range (above it).
By their numbers in this assay, from the lowest: compound 1; then compound 2; then compound 3.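

In this assay, binding does not weaken in even stages as this substituent grows: the first enlargement gave only a modest rise, whereas ethyl to isobutyl gives a 32-fold higher number from compound 2 to compound 3 (1.50 log units; beyond the scatter). Taken end to end, the change amounts to a 79-fold higher number from compound 1 to compound 3 (1.90 log units; beyond the scatter), nearly all of it arising in the last enlargement. Nothing available explains why isobutyl costs so much. As far as these compounds go, whether branching matters remains open: an unbranched butyl chain at this place would test that, and a cyclopropyl ring would show how a compact ring compares.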